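This account rests on a few compounds, and the source may have more. Where it says the series, first, only, none or still open, it means among the compounds named here.

Compound 1 `CC(=O)N[C@@H](CSC(=S)NCCCNC(=S)SC[C@H](NC(C)=O)C(=O)O)C(=O)O` and compound 2 `CC(=O)N[C@@H](CSC(=S)NCCCCNC(=S)SC[C@H](NC(C)=O)C(=O)O)C(=O)O` have open-chain linkers, whereas compound 3 `CC(=O)N[C@@H](CSC(=S)Nc1cccc(NC(=S)SC[C@H](NC(C)=O)C(=O)O)c1)C(=O)O` has a six-membered aromatic ring of carbon only in that part of the molecule. In a functional assay on LoVo/DX cells (Homo sapiens) for antiproliferative activity, read by sulforhodamine B assay, with a stated time of 72 h (on this read-out lower numbers stand for stronger inhibition and higher numbers for weaker inhibition), compound 1 gives 9550 nM and compound 2 gives 4840 nM, two values within the usual scatter of each other. Compound 3 reads > 25000 nM, which is a limit of the assay and not a number.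

Compound 4 `CC(=O)N[C@@H](CSC(=S)Nc1ccc(C)c(NC(=S)SC[C@H](NC(C)=O)C(=O)O)c1)C(=O)O` differs from compound 3 in one place: methyl in place of hydrogen on an aromatic carbon. For the measured compounds named here, no measured pair shows what such a change does, so no step beyond the usual scatter is expected in this assay, in either direction. The only anchor for this expectation is compound 3 at > 25000 nM, again a limit. The estimated step is an at least 1.1-fold lower number from compound 3 to compound 4 (0.05 log units; that floor lies within the scatter). For compound 4 the expected value is 22000 nM, with an estimated range from 10000 nM to 40000 nM.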

Compound 4, half-maximal inhibitory concentration: 22400 nM
Beside the measured number, compound 4's estimate is 1.0-fold (0.01 log units) below it, within the range that was stated.
By their numbers in this assay, from the lowest: compounds 2 and 1 (each within the scatter of the next); then compound 4. At a limit, above all of these: compound 3.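

Methyl in place of hydrogen on an aromatic carbon, ortho to a large group and para to a large group, gives in this assay an at least 1.1-fold lower number from compound 3 to compound 4 (0.04 log units; that floor lies within the scatter). Among the compounds shown with the six-membered aromatic ring in the linker, compound 4 is the only one whose value is a number and not a limit, so this ring does not by itself push a compound to the limit. The step starts from compound 3, whose value is a limit of the assay and not a number, so only its floor can be read: the limit of > 25000 nM in this assay, at which 1 of the 4 values shown sits.

On these data alone, what an amine, a methoxy group or a longer chain would do on this aromatic carbon stays open. So does the question of whether methyl on another carbon of the ring would give a similar number.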